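From 5-cyanopentyl to cycloheptyl on an aromatic nitrogen

The compounds below may be only part of what the source reports. "The series", "measured", "known", "first", "only" and "open" are said of these compounds alone.

In a functional assay on HT-29 cells (Homo sapiens) for inhibition, read by luminescence and CellTiter-Glo, with a stated time of 24 h (on this read-out higher numbers stand for an effect only at larger amounts of compound and lower numbers for an effect already at smaller amounts), compound 1 `COCCn1nc(C(=O)N[C@H]2COc3ccccc3N(C)C2=S)nc1Cc1ccccc1` gives 566 nM and compound 2 `CN1C(=S)[C@@H](NC(=O)c2nc(Cc3ccccc3)n(CCCCCC#N)n2)COc2ccccc21` gives 3830 nM as the higher of the two numbers. Compound 3 `CN1C(=S)[C@@H](NC(=O)c2nc(Cc3ccccc3)n(C3CCCCCC3)n2)COc2ccccc21` has not yet been measured. Its difference from compound 2 is cycloheptyl in place of 5-cyanopentyl on an aromatic nitrogen and a chain without a ring gives way to a ring of carbon only. Within the data shown here, one measured step bears on this change (a 6.8-fold higher number from compound 1 to compound 2 (0.83 log units; beyond the scatter)) and it was modest. That step also altered the group on the aromatic nitrogen, but it brought in no ring, so it offers a size and no firm direction. No step beyond the scatter is therefore expected in this assay. The estimated change is small (a 1.7-fold lower number from compound 2 to compound 3 (0.24 log units; within the scatter)). For compound 3 the expected value is 2200 nM within an estimated range of 450 nM to 9000 nM in this assay as well.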

Compound 3, half-maximal effective concentration: 5530 nM
Compound 3: the middle estimate sits 2.5-fold (0.40 log units) below what was measured; the measured number falls inside the stated range.
By their numbers in this assay, from the lowest: compound 1; then compounds 2 and 3 (each within the scatter of the next).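

In this assay, cycloheptyl in place of 5-cyanopentyl on the aromatic nitrogen gives a 1.4-fold higher number from compound 2 to compound 3 (0.16 log units; within the scatter), so at this position a ring of carbon only and a nitrile-ended chain without a ring cannot be told apart. Cycloheptyl in place of 2-methoxyethyl gives a 9.8-fold higher number from compound 1 to compound 3 (0.99 log units; beyond the scatter), and with the earlier step this leaves 2-methoxyethyl in compound 1 as the one group of the three whose number stands apart, beyond the scatter from both others. No measurement is at hand that accounts for these numbers.

Open, from the compounds shown here alone, is how a butyl chain, with carbon in place of the ether oxygen of 2-methoxyethyl, would compare with compound 1 on this nitrogen. Also open, going by these compounds, is where a tetrahydropyranyl ring or a chain ending in an amine would fall.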